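The source may report more compounds than this note shows. Statements on the series, on what has been measured and on what is new or still open speak of the compounds shown alone.

Measured so far in a functional assay on HT-29 cells (Homo sapiens) for cytotoxicity, read by MTT assay, with a stated time of 72 h; on this read-out higher numbers stand for weaker inhibition and lower numbers for stronger inhibition:
compound 1 `CN(C)CCn1cnnc1-c1cc(Oc2ccc(NC(=O)N/N=C/c3c(Cl)cccc3Cl)cc2F)ccn1` gives 280 nM;
compound 2 `CN(C)CCn1cnnc1-c1cc(Oc2ccc(NC(=O)N/N=C/c3ccccc3O[N+](=O)[O-])cc2F)ccn1` gives 950 nM;
compound 3 `CN(C)CCn1cnnc1-c1cc(Oc2ccc(NC(=O)N/N=C/c3ccc(O)cc3)cc2F)ccn1` gives 1920 nM.

All three share one core and differ only in the aromatic group on a carbon with a double bond to nitrogen. Within this small set compound 2 stands second highest, that is the middle of the three: compound 1 sits lower, a 3.4-fold higher number from compound 1 to compound 2 (0.53 log units; beyond the scatter), and compound 3 sits higher, a 2.0-fold higher number from compound 2 to compound 3 (0.31 log units; beyond the scatter).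

Compound 4 `COc1cc(/C=N/NC(=O)Nc2ccc(Oc3ccnc(-c4nncn4CCN(C)C)c3)c(F)c2)ccc1O` is the unmeasured member. The change from compound 2 is 4-hydroxy-3-methoxyphenyl in place of 2-(nitrooxy)phenyl on a carbon with a double bond to nitrogen.

Within the data shown here, the step that bears most directly on this is the one to compound 3, where a 4-hydroxyphenyl also replaced the 2-(nitrooxy)phenyl and the number rose, a 2.0-fold higher number from compound 2 to compound 3 (0.31 log units; beyond the scatter). The larger step of a 6.9-fold higher number from compound 1 to compound 3 (0.84 log units; beyond the scatter) points the same way, with the 4-hydroxyphenyl giving the highest number seen. Compound 4 carries the same 4-hydroxy group plus a methoxy, so a modest rise of roughly the size seen for compound 3 is expected, and a number near that of compound 3 is the estimate, a 1.9-fold higher number from compound 2 to compound 4 (0.28 log units; within the scatter).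

For compound 4 in this assay the expected value is 1800 nM, with a likely range from 700 nM to 4500 nM.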

Compound 4, half-maximal inhibitory concentration: 120 nM
Estimate against measurement, compound 4: 15-fold (1.18 log units) above; the whole stated range lies above it.
By their numbers in this assay, from the lowest: compound 4; then compound 1; then compound 2; then compound 3.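

In this assay, the methoxy in place of hydrogen on an aromatic carbon gives a 16-fold lower number from compound 3 to compound 4 (1.20 log units; beyond the scatter) as the largest step in this set, so the 4-hydroxyphenyl result alone did not predict what the 4-hydroxy-3-methoxyphenyl group would do. The new group also gives a 7.9-fold lower number from compound 2 to compound 4 (0.90 log units; beyond the scatter) when it replaces 2-(nitrooxy)phenyl and a 2.3-fold lower number from compound 1 to compound 4 (0.37 log units; beyond the scatter) when it replaces 2,6-dichlorophenyl, so compound 4 now has the lowest number of the four, with all three steps beyond the usual scatter. This shows that one small addition to the ring on the carbon with a double bond to nitrogen can move a compound from the highest number in the set to the lowest, though nothing here explains why this happens.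

Going by these compounds, what remains open is whether the methoxy would have a similar effect without the 4-hydroxy group on the same ring. It is also unclear whether an ethoxy, a longer alkoxy chain or an amine in place of the methoxy would keep the number this low.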